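The source may hold more compounds than are shown below. What is called first, only, known or untested is meant among the compounds shown, and "the series" means these compounds.

Compound 1 `CN1CCC(c2ccc3c(c2)oc(=O)n3C(=O)NCCCCc2ccccc2)CC1=O` is the starting point of this step. In a physicochemical assay for solubility, read by HPLC, in phosphate buffer, measured as kinetic solubility, with a stated time of 1 h, at pH 7.4, tested at 250 uM (on this read-out higher numbers stand for higher solubility and lower numbers for lower solubility), compound 1 gives 20000 nM, the lowest of the three numbers in hand; compound 2 `CC(C)CNC(=O)n1c(=O)oc2c(C3CCN(C)CC3)cccc21` gives 230000 nM and compound 3 `CC(C)CNC(=O)n1c(=O)oc2cc(C3CCN(C)CC3)ccc21` gives 240000 nM, both beyond the scatter above compound 1. No step between measured compounds is available, so nothing here can be read as a cause. Compound 4 `CCN1CCC(c2ccc3c(c2)oc(=O)n3C(=O)NCCCCc2ccccc2)CC1` differs from compound 1 in one place: 1-ethylpiperidin-4-yl in place of 1-methyl-2-oxopiperidin-4-yl on an aromatic carbon. An upward step from compound 1 to compound 4 is expected in this assay, beyond the scatter, since compound 2 and compound 3 give the higher values shown above. The estimate is a 4.5-fold higher number from compound 1 to compound 4 (0.65 log units; beyond the scatter). Compound 4 is expected at 90000 nM, within 30000 nM to 240000 nM.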

Compound 4, solubility: 198000 nM
Estimate against measurement, compound 4: 2.2-fold (0.34 log units) below; low and high end bracket the measured number.
By their numbers in this assay, from the lowest: compound 1; then compounds 4, 2 and 3 (each within the scatter of the next).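

In this assay, this aromatic carbon now has a first readable step, a 9.9-fold higher number from compound 1 to compound 4 (1.00 log units; beyond the scatter), for 1-ethylpiperidin-4-yl in place of 1-methyl-2-oxopiperidin-4-yl with the rest of the molecule unchanged. The two groups have the same count of 8 heavy atoms and each has one six-membered non-aromatic ring, differing in the ring carbonyl and in methyl against ethyl on the ring nitrogen. No measurement shown here explains the step.

The contributions of the carbonyl and the nitrogen substituent remain unseparated, and 1-ethyl-2-oxopiperidin-4-yl on this core would divide them. Going by these compounds, whether the step carries over to a morpholine ring at this position also stays open.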